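Amide variation on the proline-nitrile series

The source may report more compounds than this note shows. Statements on the series, on what has been measured and on what is new or still open speak of the compounds shown alone.

Measured compounds in an assay on the whole organism (plasma, strain Sprague-Dawley) for inhibition of Dipeptidyl peptidase 4 (Rattus norvegicus), with a stated time of 6 h, at a dose of 1 mg/kg by the oral route; on this read-out higher numbers stand for more inhibition at the one dose given (going by the name of the read-out) and lower numbers for less inhibition:
compound 1 `CCCNC(=O)[C@@H]1CN[C@H](C(=O)N2CCC[C@H]2C#N)C1` gives 59%
compound 2 `C[C@@H]1N[C@H](C(=O)N2CCC[C@H]2C#N)C[C@@H]1C(=O)N1CCOCC1` gives 94%
compound 3 `C[C@@H]1N[C@H](C(=O)N2CCC[C@H]2C#N)C[C@@H]1C(=O)N1CCCC1` gives 94%

Compound 1 stands lowest of the three in this assay; compound 2 and compound 3, which carry a methyl on the shared core that compound 1 lacks, both lie well beyond the scatter above it. Going by the values given here, the one step measured is the exchange of the group on the carbonyl carbon, no change at the digits printed from compound 2 to compound 3 (within the scatter), so between these two amides the read-out did not move.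

Compound 4 `CCN(C)C(=O)[C@@H]1CN[C@H](C(=O)N2CCC[C@H]2C#N)C1` is compound 1 with ethyl(methyl)amino in place of propylamino on a carbonyl carbon. Among the compounds with values here, no step measured here connects a propylamino amide with any other amide on an otherwise unchanged core, so the only guidance is the flat step from compound 2 to compound 3, which also alters the group on the carbonyl carbon. On that basis the step in this assay is expected to stay within the scatter, at most a small rise: the estimated change is a number 5 percentage points higher from compound 1 to compound 4 (within the scatter). Compound 4 is therefore estimated at 64%, with a range of 45% to 84%.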

Compound 4, a percentage reported as inhibition, in the whole organism at one dose (the size of the read-out at that dose, not a potency): 71%
Compound 4: middle estimate off by 7 percentage points, on the low side; the range from low to high includes it.
By their numbers in this assay, from the lowest: compound 1; then compound 4; then compounds 2 and 3 (each within the scatter of the next).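

In this assay, the exchange of propylamino for ethyl(methyl)amino on a carbonyl carbon gives a number 12 percentage points higher from compound 1 to compound 4 (beyond the scatter), so the read-out can respond to the group at this place, which the earlier amide exchange, with no change at the digits printed from compound 2 to compound 3 (within the scatter), did not show. The change keeps the same atoms, joined differently, and the entering group lacks the amide hydrogen that propylamino carries, yet a single pair cannot tie the step to that hydrogen or to any other feature. No supporting data bear on why the read-out moved in this step.

Going by these compounds, it remains open whether a dimethylamino or butylamino group on the core of compound 1 would follow compound 4 or compound 1. The compounds shown also leave open how propylamino and ethyl(methyl)amino compare on the methyl-bearing core of compound 2.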